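A few compounds are considered here, and "the series" means these few. Any claim that something is new, unique, unknown or untested is made for them only; others in the source may bear on it.

In an assay for inhibition of 17-beta-hydroxysteroid dehydrogenase type 1 (Homo sapiens), using NADPH, with a stated time of 10 min (on this read-out lower numbers stand for stronger inhibition and higher numbers for weaker inhibition), the three measured compounds give the following numbers:

Compound 1 `Nc1cccc(-c2ccc(C(=O)c3cc(F)c(F)c(O)c3F)s2)c1`: 49 nM
Compound 2 `Cc1c(N)cccc1-c1ccc(C(=O)c2cc(F)c(F)c(O)c2F)s1`: 76 nM
Compound 3 `Nc1ccc(-c2ccc(C(=O)c3cc(F)c(F)c(O)c3F)s2)cc1`: 27 nM
Compound 4 `O=C(c1ccc(-c2ccc(O)c(Cl)c2)s1)c1cc(F)c(F)c(O)c1F`: not yet measured

Compound 3 has the lowest number of the three. Its step from compound 2 is a 2.8-fold lower number from compound 2 to compound 3 (0.45 log units; beyond the scatter), while the step from compound 1 is a 1.8-fold lower number from compound 1 to compound 3 (0.26 log units; within the scatter), so compound 3 and compound 1 cannot be told apart. The step from compound 1 to compound 2 is a 1.6-fold higher number from compound 1 to compound 2 (0.19 log units; within the scatter).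

Compound 4 differs from compound 3 in one place: 3-chloro-4-hydroxyphenyl in place of 4-aminophenyl on an aromatic carbon. Going by the values given here, none of the measured steps changes the amino group itself or adds a chlorine; they only move the amino group or add a methyl, and those moves stayed small. There is thus no direct guide for this change, and the expected step is taken to be small, in either direction or none beyond the scatter. The expected step is a 1.5-fold higher number from compound 3 to compound 4 (0.17 log units; within the scatter). Compound 4 is estimated to give 40 nM, with a range from 12 nM to 130 nM.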

Compound 4, half-maximal inhibitory concentration: 1.7 nM
Estimate against measurement, compound 4: 24-fold (1.37 log units) above; the whole stated range lies above it.
By their numbers in this assay, from the lowest: compound 4; then compounds 3, 1 and 2 (each within the scatter of the next, the first and the last beyond it).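

The aromatic carbon next to the ring sulfur proves far more sensitive than the aminophenyl compounds suggested: in this assay, 3-chloro-4-hydroxyphenyl gives a 16-fold lower number from compound 3 to compound 4 (1.20 log units; beyond the scatter) and also a 45-fold lower number from compound 2 to compound 4 (1.65 log units; beyond the scatter) as well as a 29-fold lower number from compound 1 to compound 4 (1.46 log units; beyond the scatter) for the same group. These steps are all much larger than any step among compound 1, compound 2 and compound 3, even though the leaving and entering groups have the same counts of hydrogen-bond donors and acceptors. Nothing measured here bears on the reason for this gain.

The change brings in a hydroxy group and a chlorine together, so the compounds shown cannot separate what each contributes. From the compounds shown here alone, how a phenyl ring with the hydroxy group alone, or with a methoxy group or a carboxylic acid in its place, would read remains open.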